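Methoxy for methyl on the anilide of compound 3

A few compounds are considered here, and "the series" means these few. Any claim that something is new, unique, unknown or untested is made for them only; others in the source may bear on it.

Compound 1 `O=C(O)CCC(=O)OCCCCCCSc1ccc([N+](=O)[O-])c2nonc12` gives 160 nM in an assay on isolated protein for inhibition of glutathione S-transferase Mu 2 (Homo sapiens), with a stated time of 10 min; on this read-out higher numbers stand for weaker inhibition and lower numbers for stronger inhibition.
Compound 2 `O=C(CCC(=O)OCCCCCCSc1ccc([N+](=O)[O-])c2nonc12)Nc1ccccc1F` gives 350 nM in this assay.
Compound 3 `Cc1ccccc1NC(=O)CCC(=O)OCCCCCCSc1ccc([N+](=O)[O-])c2nonc12` gives 440 nM in this assay.

Compound 3 has the highest number of the three. Its neighbour is compound 2, and the step of a 1.3-fold higher number from compound 2 to compound 3 (0.10 log units; within the scatter) lies within the scatter, so the two cannot be ordered. The step of a 2.8-fold higher number from compound 1 to compound 3 (0.44 log units; beyond the scatter) is modest but beyond the scatter, as is a 2.2-fold higher number from compound 1 to compound 2 (0.34 log units; beyond the scatter); both anilides sit above the free acid of compound 1.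

Compound 4 `COc1ccccc1NC(=O)CCC(=O)OCCCCCCSc1ccc([N+](=O)[O-])c2nonc12` differs from compound 3 in one place: methoxy in place of methyl on an aromatic carbon. Among the compounds with values here, the only measured step that bears directly on a change at this position is a 1.3-fold higher number from compound 2 to compound 3 (0.10 log units; within the scatter), a swap of one small group for another on the same aromatic carbon, which stayed within the scatter. The two steps from compound 1 concern the whole anilide and say nothing about the substituent on its ring. On that basis the step of a 1.0-fold higher number from compound 3 to compound 4 (0.01 log units; within the scatter) is expected to stay within the scatter, with no clear direction. Compound 4 is therefore estimated at 450 nM, with a range from 200 nM to 1000 nM.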

Compound 4, half-maximal inhibitory concentration: 280 nM
For compound 4 the middle estimate is 1.6-fold (0.21 log units) above the measured one; measured number inside the range.
By their numbers in this assay, from the lowest: compounds 1, 4, 2 and 3 (each within the scatter of the next, the first and the last beyond it).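

In this assay, a 1.6-fold lower number from compound 3 to compound 4 (0.20 log units; within the scatter) and a 1.3-fold lower number from compound 2 to compound 4 (0.10 log units; within the scatter) both lie within the scatter, so methyl, fluoro and methoxy on this aromatic carbon cannot be ordered, even though methoxy brings a hydrogen-bond acceptor that methyl does not carry. What compound 4 adds concerns the comparison with the free acid: a 1.8-fold higher number from compound 1 to compound 4 (0.24 log units; within the scatter) also lies within the scatter, whereas a 2.2-fold higher number from compound 1 to compound 2 (0.34 log units; beyond the scatter) and a 2.8-fold higher number from compound 1 to compound 3 (0.44 log units; beyond the scatter) lie beyond it, so the earlier reading of both anilides as separated from compound 1 does not extend to all three. Nothing shown here explains why these steps fall as they do.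

The compounds shown leave open whether an unsubstituted phenyl ring, or a carboxylic acid, an amine or a longer alkoxy chain on this same aromatic carbon, would stay within the scatter of compounds 2, 3 and 4. They also leave open whether a methoxy group placed elsewhere on the ring would read the same, since every substituted anilide here carries its group at this one position.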